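Swapping methyl for trifluoromethyl on the quinoline-like core

A few compounds are considered here, and "the series" means these few. Any claim that something is new, unique, unknown or untested is made for them only; others in the source may bear on it.

Of the compounds shown here, three have been measured in a functional assay on Hep 3B2 cells (Homo sapiens) for antiproliferative activity, read by MTT assay, with a stated time of 24 h, tested at 0.01 ug/mL; on this read-out higher numbers stand for a stronger effect at the one concentration tested and lower numbers for a weaker effect. Compound 1 `Cc1ccc2nc(C(=O)Nc3c(F)cc(-c4cccc(F)c4)cc3F)c(C)c(O)c2c1` gives 0.22%, and compound 2 `Cc1c(C(=O)Nc2ccc(-c3ccccc3)cc2)nc2ccccc2c1O` gives 0.23%. Among the measured compounds shown here, compound 3 `Cc1ccc2nc(C(=O)Nc3c(F)cc(-c4cccc(F)c4)cc3F)c(C)c(C(=O)O)c2c1` gives 0.36%, the largest of the three figures, though each gap to it is within the scatter: the one measured step, a number 0.1 percentage points higher from compound 1 to compound 3 (within the scatter), is within the scatter, and the figures of compound 2 and compound 3 differ by a similar small amount. All three, in effect, show almost no inhibition at this concentration.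

Compound 4 `Cc1c(C(=O)Nc2c(F)cc(-c3cccc(F)c3)cc2F)nc2ccc(C(F)(F)F)cc2c1C(=O)O` is not yet measured. It differs from compound 3 in one place: trifluoromethyl in place of methyl on an aromatic carbon. For the measured compounds named here, no measured step involves this exchange, so nothing points to a change beyond the scatter. Going by the values given here, the single step measured, from a hydroxy to a carboxy group, stayed within the scatter, and the three starting figures are all near zero. Compound 4 is therefore expected to give 0.4% in this assay, within -6% to 8%, meaning an expected step of a number 0 percentage points higher from compound 3 to compound 4 (within the scatter), which is no change beyond the scatter.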

Compound 4, a percentage reported as inhibition, at one concentration (the size of the read-out at that concentration, not a potency): 0.2%
The estimate for compound 4 lay 0.2 percentage points above the measured number; measured number inside the range.
By their numbers in this assay, from the lowest: compounds 4, 1, 2 and 3 (each within the scatter of the next).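

In this assay, among the compounds shown here, trifluoromethyl in place of methyl on this aromatic carbon gives a number 0.2 percentage points lower from compound 3 to compound 4 (within the scatter), so a group of 4 heavy atoms in place of 1 at a position no earlier step had touched brings no change beyond the scatter. Both figures lie close to zero at the one concentration tested, so this result says little about how the position would behave in a compound that inhibits clearly. No measurement shown here offers an explanation for this result.

From the compounds shown here alone, whether an amine, a methoxy group or a chlorine atom on this same aromatic carbon would give a figure beyond the scatter remains open. Also open, going by these compounds, is whether compounds with either methyl or trifluoromethyl here would differ at a higher concentration, where inhibition might be large enough to compare.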